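Compound 4: isobutyl in place of tert-butoxy

The compounds below may be only part of what the source reports. "The series", "measured", "known", "first", "only" and "open" are said of these compounds alone.

In an assay on membranes from CHO cells for displacement of a labelled ligand from adenosine receptor A1 (Homo sapiens), read by scintillation counting, with a stated time of 60 min, tested at 1 uM (on this read-out lower numbers stand for less inhibition and higher numbers for more inhibition at the one concentration tested (going by the name of the read-out)), compound 1 `CC1=C(C(=O)OC(C)(C)C)C(c2cccs2)NC(=O)N1` gives 26%, the second highest of the three numbers. Compound 2 `CC1=C(C(=O)OCc2ccccc2)C(c2cccs2)NC(=O)N1` gives 45% in this assay; the step of a number 19 percentage points higher from compound 1 to compound 2 (beyond the scatter) is beyond the scatter. Compound 3 `CC1=C(C(=O)OC(C)(C)C)C(c2cccs2)NC(=O)N1C` gives 18% in this assay; the step of a number 8 percentage points lower from compound 1 to compound 3 (within the scatter) stays within the scatter. Compound 4 `CC1=C(C(=O)CC(C)C)C(c2cccs2)NC(=O)N1` differs from compound 1 by isobutyl in place of tert-butoxy on a carbonyl carbon. Neither measured step makes this change; only a number 19 percentage points higher from compound 1 to compound 2 (beyond the scatter) touches the same carbonyl, and it keeps an oxygen there. Going by the values given here, with no direct precedent, the step of a number 2 percentage points higher from compound 1 to compound 4 (within the scatter) expected in this assay is none beyond the scatter. Compound 4 is therefore estimated at 28% in this assay, in a range from 8% to 50%.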

Compound 4, a percentage reported as inhibition, at one concentration (the size of the read-out at that concentration, not a potency): 19%
Compound 4: the middle estimate sits 9 percentage points above what was measured; the range from low to high includes it.
By their numbers in this assay, from the lowest: compounds 3, 4 and 1 (each within the scatter of the next); then compound 2.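

Working from compound 1 in this assay the change reads as a number 7 percentage points lower from compound 1 to compound 4 (within the scatter) and so gives no sign that this carbonyl carbon needs the oxygen of tert-butoxy. Going by these compounds alone, earlier compounds varied the group on that oxygen but kept the oxygen itself, so this is the first view of the position without it. No measured information bears on why this replacement reads as it does.

Still open, as far as these compounds go, is how a benzyl group placed directly on this carbonyl carbon would read. From the compounds shown here alone, a carboxylic acid or an amine-derived amide at this position also remains open.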